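Notes on the nitro-to-methyl-to-methoxy series

The compounds below may be only part of what the source reports. "The series", "measured", "known", "first", "only" and "open" are said of these compounds alone.

Measured so far:
compound 1, `Nc1ccccc1NC(=O)c1ccc(NCC(=O)Nc2ccc([N+](=O)[O-])cc2)cc1`, 77.5% in a functional assay on the whole organism (Ehrlich cells, Mus musculus) for antiproliferative activity, with a stated time of 24 h, at a dose of 0.2 mmol/kg by the intraperitoneal route; on this read-out higher numbers stand for more inhibition at the one dose given (going by the name of the read-out) and lower numbers for less inhibition
compound 2, `Cc1ccc(NC(=O)CNc2ccc(C(=O)Nc3ccccc3N)cc2)cc1`, 25.2%

Going by the values given here, compound 2 gives the lower of the two numbers; the only step here, a number 52.3 percentage points lower from compound 1 to compound 2 (beyond the scatter), is a large drop set off by putting methyl in place of nitro on an aromatic carbon. Compound 3, `COc1ccc(NC(=O)CNc2ccc(C(=O)Nc3ccccc3N)cc2)cc1`, is not yet measured. It differs from compound 2 by methoxy in place of methyl on an aromatic carbon. Among the compounds with values here, no measured step changes methyl to methoxy, so only the size of the step from compound 1 to compound 2 bears on it: it shows that the group at this position can move the read-out strongly, but gives no direction for a methoxy. The estimate for compound 3 is therefore kept near compound 2 with a wide range; compound 3 is expected to give about 35%, within 10% to 65%, a step of a number 9.8 percentage points higher from compound 2 to compound 3 (within the scatter) that is expected to stay close to the scatter.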

Compound 3, a percentage reported as inhibition, in the whole organism at one dose (the size of the read-out at that dose, not a potency): 62.3%
For compound 3 the middle estimate is 27.3 percentage points below the measured one; low and high end bracket the measured number.
By their numbers in this assay, from the lowest: compound 2; then compound 3; then compound 1.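

Methoxy in place of methyl gives a number 37.1 percentage points higher from compound 2 to compound 3 (beyond the scatter) in this assay, so the aromatic carbon para to a large group responds strongly to a change other than the loss of nitro, and this change has an upward direction. Methoxy in place of nitro still leaves a number 15.2 percentage points lower from compound 1 to compound 3 (beyond the scatter) as a modest step, which sets the three groups in the order methyl, methoxy, nitro from the lowest number to the highest. Nothing at hand accounts for this order or ties it to any property of the groups.

Open, from the compounds shown here alone, is how a hydroxyl, an amine or a longer chain such as ethoxy would read at this position. Also open, going by these compounds, is whether the order of the three groups holds at other doses, since each number here comes from a single dose.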